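The source may hold more compounds than are shown below. What is called first, only, known or untested is meant among the compounds shown, and "the series" means these compounds.

The study concerns three measured compounds and one awaiting measurement, all built on a shared core and differing in the groups attached to it. Compound 1, `Cc1c(Br)sc(N)c1C(=O)c1ccc(Cl)cc1`, was tested in an assay on CHO cells for displacement of a labelled ligand from adenosine receptor A3 (Homo sapiens), read by scintillation counting, tested at 10 uM (on this read-out higher numbers stand for more inhibition at the one concentration tested (going by the name of the read-out) and lower numbers for less inhibition), where compound 1 gives 1%. Compound 2, `CC(C)(C)Cc1csc(N)c1C(=O)c1cccc(Cl)c1`, gives 8% in this assay. Compound 3, `CC(C)(C)Cc1c(-c2ccoc2)sc(N)c1C(=O)c1ccc(Cl)cc1`, gives 1% in this assay, which is level with compound 1 at the digits reported, and together these two compounds are the lowest of the three numbers; compound 2 sits a little higher, but still within the usual scatter of such measurements, so no order among the three can be read from the data.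

Compound 4, `CC(C)(C)Cc1c(-c2ccc(F)cc2)sc(N)c1C(=O)c1ccc(Cl)cc1`, is the next step from compound 3. The change is 4-fluorophenyl in place of furan-3-yl on an aromatic carbon. Among the compounds with values here, no measured pair shows what such a change does, so nothing can be inferred from the existing steps. Compound 4 is expected to give 3% in this assay, with a range from -6% to 14%, because compound 3 gives 1% and the expected step of a number 2 percentage points higher from compound 3 to compound 4 (within the scatter) is none beyond the scatter.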

Compound 4, a percentage reported as inhibition, at one concentration (the size of the read-out at that concentration, not a potency): 9%
Compound 4: the middle estimate sits 6 percentage points below what was measured; low and high end bracket the measured number.
By their numbers in this assay, from the lowest: compounds 1, 3, 2 and 4 (each within the scatter of the next).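

Placing 4-fluorophenyl in place of furan-3-yl on this aromatic carbon, next to the ring sulfur and next to the ring atom that bears a neopentyl group, gives in this assay a number 8 percentage points higher from compound 3 to compound 4 (within the scatter). Within the data shown here, this is the first step read at this position, and it shows that exchanging a five-membered aromatic ring with 1 hetero atom for a six-membered aromatic ring of carbon only does not move the number beyond the scatter. Nothing available bears on why the number behaves this way.

The compounds shown leave open whether another group at this position, such as an amine, a carboxylic acid or a longer chain, would move the number beyond the scatter. They also leave open whether a plain phenyl would read any differently from 4-fluorophenyl.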